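The source may hold more compounds than are shown below. What is called first, only, known or untested is meant among the compounds shown, and "the series" means these compounds.

In an ADME assay on L6 cells (Rattus norvegicus) for cytotoxicity (on this read-out higher numbers stand for weaker inhibition and lower numbers for stronger inhibition), compound 1 `CN1CCN(CCC(=O)OC2CC3(N(C)C)CC(c4ccccc4)C2C(c2ccccc2)C3)CC1` reads 31100 nM while compound 2 `CN1CCN(CCC(=O)NC2CC3(N4CCN(C)CC4)CC(c4ccccc4)C2C(c2ccccc2)C3)CC1` reads 67900 nM as the higher of the two numbers, a gap beyond the usual scatter of repeated measurements. Compound 2 is therefore the weaker inhibitor of this pair. The two compounds differ in more than one place, so their gap cannot be tied to any single change. Compound 3 `CN1CCN(CC(=O)NC2CC3(N4CCN(C)CC4)CC(c4ccccc4)C2C(c2ccccc2)C3)CC1` departs from compound 2 in one place only: 4-methylpiperazin-1-yl in place of (4-methylpiperazin-1-yl)methyl on a saturated chain carbon bound to a carbonyl carbon describes the difference, with 4-methylpiperazin-1-yl in place of (4-methylpiperazin-1-yl)methyl on a saturated chain carbon bound to a carbonyl carbon. Among the compounds with values here, no measured pair shows this change, so there is no direct guide to its effect. What is expected is a 1.1-fold lower number from compound 2 to compound 3 (0.05 log units; within the scatter) with no clear direction and no shift beyond the scatter. In this assay compound 3 is estimated at 60000 nM with an expected range from 30000 nM to 120000 nM across repeated measurements.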

Compound 3, half-maximal inhibitory concentration: 42100 nM
Beside the measured number, compound 3's estimate is 1.4-fold (0.15 log units) above it; low and high end bracket the measured number.
By their numbers in this assay, from the lowest: compounds 1, 3 and 2 (each within the scatter of the next, the first and the last beyond it).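

In this assay, within the data shown here, this pair gives the first reading of a single change: 4-methylpiperazin-1-yl in place of (4-methylpiperazin-1-yl)methyl on a saturated chain carbon bound to a carbonyl carbon gives a 1.6-fold lower number from compound 2 to compound 3 (0.21 log units; within the scatter). Seen one bond further out, 2-(4-methylpiperazin-1-yl)ethyl gives way to (4-methylpiperazin-1-yl)methyl on the amide without a shift beyond the scatter, so this read-out does not separate the two chains. Nothing measured alongside these numbers speaks to the reason for this result.

This single pair leaves open whether the same holds for a longer chain, such as 3-(4-methylpiperazin-1-yl)propyl. It also leaves open how a morpholine ring would read at this place in place of the 4-methylpiperazin-1-yl group.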